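Phenyl for benzyl on a urea of a weak tryptophan dioxygenase inhibitor

The source may report more compounds than this note shows. Statements on the series, on what has been measured and on what is new or still open speak of the compounds shown alone.

Measured compounds:
compound 1 `NS(=O)(=O)N1CCC(C(=O)/C(=N/O)Nc2ccc(F)c(Br)c2)CC1` 62500 nM
compound 2 `O=C(/C(=N/O)Nc1ccc(F)c(Br)c1)C1CCN(C(=O)NCc2ccccc2)CC1` 89800 nM
compound 3 `O=C(NC[C@H]1CC[C@H](C(=O)/C(=N/O)Nc2ccc(F)c(Br)c2)CC1)c1ccccc1` 81000 nM

All three were tested in an assay for inhibition of Tryptophan 2,3-dioxygenase (Homo sapiens), with a stated time of 1 h (on this read-out lower numbers stand for stronger inhibition and higher numbers for weaker inhibition), and all three inhibit only weakly. Compound 2 gives the highest number of the three in this assay, but its gaps to compound 1 and to compound 3 are within the scatter, so the three stand level. Among the measured compounds shown here, the one single-point step among them, a 1.4-fold higher number from compound 1 to compound 2 (0.16 log units; within the scatter), also stayed within the scatter.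

Compound 4 `O=C(/C(=N/O)Nc1ccc(F)c(Br)c1)C1CCN(C(=O)Nc2ccccc2)CC1` differs from compound 2 by phenyl in place of benzyl on an amide-type nitrogen. For the measured compounds named here, no measured step bears on this exact change. With the measured values so close together, the expectation for compound 4 is a number near that of compound 2 and no step beyond the scatter: a 1.1-fold lower number from compound 2 to compound 4 (0.05 log units; within the scatter). Compound 4 is thus estimated at 80000 nM, with a range from 30000 nM to 200000 nM.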

Compound 4, half-maximal inhibitory concentration: 58000 nM
For compound 4 the middle estimate is 1.4-fold (0.14 log units) above the measured one; the range from low to high includes it.
By their numbers in this assay, from the lowest: compounds 4, 1, 3 and 2 (each within the scatter of the next).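

In this assay phenyl in place of benzyl on the amide-type nitrogen gives a 1.5-fold lower number from compound 2 to compound 4 (0.19 log units; within the scatter) and so does not move the number beyond the scatter. Phenylcarbamoyl in place of sulfamoyl on the amine nitrogen in the ring gives a 1.1-fold lower number from compound 1 to compound 4 (0.03 log units; within the scatter) and also stays within the scatter, so compounds 1, 2 and 4 stand level with three different groups at this nitrogen. No measured evidence here bears on this result. Going by these compounds, whether a carboxylic acid or an amine on the phenyl, or a longer chain in its place, would give a step beyond the scatter remains open.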